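The source may report more compounds than this note shows. Statements on the series, on what has been measured and on what is new or still open speak of the compounds shown alone.

Of the compounds shown here, two measured so far share a core that ends in a hydroxamic acid. Compound 1 `O=C(NO)c1ccc(Cn2nnc(Cc3ccccc3)n2)cc1` carries a benzyl group on that core, and compound 2 `O=C(NO)c1ccc(Cn2nnc(-c3ccccc3)n2)cc1` carries a phenyl group instead. In an assay on Sf9 cells for inhibition of protein deacetylase HDAC6 (Homo sapiens), read by fluorescence (on this read-out lower numbers stand for stronger inhibition and higher numbers for weaker inhibition), compound 1 gives 52 nM and compound 2 gives 3 nM. That step is a 17-fold lower number from compound 1 to compound 2 (1.24 log units; beyond the scatter). Compound 2 thus stands with the lowest number of the two measured, and the nearest number, that of compound 1, is well beyond the scatter from it. Compound 3 `NCc1ccc(-c2nnn(Cc3ccc(C(=O)NO)cc3)n2)cc1` has not yet been measured in this assay; it differs from compound 2 by aminomethyl in place of hydrogen on an aromatic carbon. Within the data shown here, the single known step, a 17-fold lower number from compound 1 to compound 2 (1.24 log units; beyond the scatter), exchanges the whole group rather than adding to its far end, so it bears only loosely on this change, and no step in the data tests an addition of this kind. The expectation is therefore a change that stays close to compound 2. In this assay compound 3 is expected to give about 4 nM, with a range from 1.5 nM to 12 nM. The expected step, a 1.3-fold higher number from compound 2 to compound 3 (0.12 log units; within the scatter), is estimated to lie within the scatter.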

Compound 3, half-maximal inhibitory concentration: 2 nM
The estimate for compound 3 lay 2.0-fold (0.30 log units) above the measured number; measured number inside the range.
By their numbers in this assay, from the lowest: compounds 3 and 2 (each within the scatter of the next); then compound 1.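

Compound 3 shows that this position, on the six-membered aromatic ring and para to a large group, can take an added aminomethyl without a change that stands out: in this assay, the addition gives a 1.5-fold lower number from compound 2 to compound 3 (0.18 log units; within the scatter), which lies within the scatter. The added group also keeps the advantage over the benzyl compound, with 4-(aminomethyl)phenyl in place of benzyl giving a 26-fold lower number from compound 1 to compound 3 (1.41 log units; beyond the scatter), a large step beyond the scatter. No supporting measurement is available to explain why the aminomethyl group leaves the number within the scatter.

Among these compounds, with only this one group at the position, it remains open whether a carboxylic acid or a longer aminoethyl chain would be accepted there as well. Also open, going by these compounds, is what an aminomethyl group would do on the benzyl group of compound 1.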